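Phenoxy replacing an ester side chain on the shared core

The source may report more compounds than this note shows. Statements on the series, on what has been measured and on what is new or still open speak of the compounds shown alone.

Measured compounds:
compound 1 `O=c1cc(O)c2ccc(OCc3cccc(Br)c3)cc2o1`, 490 nM
compound 2 `CC(=O)COc1cc(=O)oc2cc(OCc3cccc(Cl)c3)ccc12`, 26.9 nM
compound 3 `CCOC(=O)COc1cc(=O)oc2cc(OCc3cccc(Cl)c3)ccc12`, 1820 nM

In an assay on isolated protein (strain Sprague-Dawley) for inhibition of Amine oxidase [flavin-containing] B (Rattus norvegicus), read by spectrophotometry, with a stated time of 5 min (on this read-out higher numbers stand for weaker inhibition and lower numbers for stronger inhibition), compound 3 gives the highest of the three numbers; compound 1 sits closest to it and compound 2 furthest away. Compound 4 `O=c1cc(Oc2ccccc2)c2ccc(OCc3cccc(Cl)c3)cc2o1` is derived from compound 3 by the change (phenyl in place of (ethoxycarbonyl)methyl on an oxygen on an aromatic ring).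

Going by the values given here, only one measured step touches the same side chain: a 68-fold higher number from compound 2 to compound 3 (1.83 log units; beyond the scatter). Among the compounds with values here, that step shows that the group on this oxygen alters the read-out strongly, but it does not involve a phenyl, so no measured pair reproduces the change to compound 4. Compound 1, which carries a hydroxyl on the corresponding oxygen and a bromo in place of the chloro, gives 490 nM, a lower number than compound 3 but a higher one than compound 2. Since both alternatives to the ethyl ester give lower numbers, compound 4 is expected to show a lower number than compound 3, a step of about a 6.1-fold lower number from compound 3 to compound 4 (0.78 log units; beyond the scatter), with wide uncertainty. Compound 4 is estimated at 300 nM, within 50 nM to 2000 nM.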

Compound 4, half-maximal inhibitory concentration: 4070 nM
Estimate against measurement, compound 4: 14-fold (1.13 log units) below, outside the stated range (above it).
By their numbers in this assay, from the lowest: compound 2; then compound 1; then compound 3; then compound 4.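

In this assay phenyl on this oxygen brings a 2.2-fold higher number from compound 3 to compound 4 (0.35 log units; beyond the scatter) and a 150-fold higher number from compound 2 to compound 4 (2.18 log units; beyond the scatter) when set against the 2-oxopropyl group. Removing the ester side chain in favour of an aromatic ring of carbon only therefore does not lower the number, as the hydroxyl-bearing compound had suggested it might. Among the three groups compared on this oxygen with the rest of the molecule unchanged, only 2-oxopropyl gives a low number, and the ethyl ester and the phenyl both stand far above it.

What the compounds shown leave open is whether a carboxylic acid, an amine or a longer chain ending in a ketone on this oxygen would hold the low number of 2-oxopropyl. No supporting measurement explains why these side chains differ so strongly.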